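This account rests on a few compounds, and the source may have more. Where it says the series, first, only, none or still open, it means among the compounds named here.

Working notes on the series. Three amide variants of the shared core have been read in a functional assay on A549 cells (Homo sapiens) for antiproliferative activity, read by CCK-8 assay, with a stated time of 72 h; on this read-out higher numbers stand for weaker inhibition and lower numbers for stronger inhibition. Compound 1 `Cc1ccc(C(=O)Nc2cccc(-c3oc4cc(-c5ccc(F)cc5)ccc4c(=O)c3O)c2)cc1` gives 6910 nM. Compound 2 `Cc1cccc(C(=O)Nc2cccc(-c3oc4cc(-c5ccc(F)cc5)ccc4c(=O)c3O)c2)c1` gives 16500 nM. Compound 3 `O=C(Nc1cccc(-c2oc3cc(-c4ccc(F)cc4)ccc3c(=O)c2O)c1)c1ccc(Br)cc1F` gives 46100 nM, the highest number of the three: against compound 2 the step is a 2.8-fold higher number from compound 2 to compound 3 (0.45 log units; beyond the scatter), against compound 1 it is a 6.7-fold higher number from compound 1 to compound 3 (0.82 log units; beyond the scatter), and between the two methylphenyl amides the step is a 2.4-fold higher number from compound 1 to compound 2 (0.38 log units; beyond the scatter). All three changes on the carbonyl carbon have moved the read-out beyond the scatter, so the amide aryl is not an indifferent position in this assay.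

Compound 4 `O=C(Nc1cccc(-c2oc3cc(-c4ccc(F)cc4)ccc3c(=O)c2O)c1)c1ccc(Cl)nc1` is the next step from compound 3: 6-chloropyridin-3-yl in place of 4-bromo-2-fluorophenyl on a carbonyl carbon. Within the data shown here, no measured pair covers a heteroaryl at this place, so the expectation rests only on the spread seen among the three aryl amides. Compound 3 carries the weakest result so far, and the measured steps around it have been modest in size; a return toward the middle of the series is the plainer expectation, though a further rise cannot be excluded. The step from compound 3 to compound 4 is therefore estimated as a 2.1-fold lower number from compound 3 to compound 4 (0.32 log units; beyond the scatter). For compound 4 in this assay the estimate is 22000 nM, with a range from 7000 nM to 70000 nM.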

Compound 4, half-maximal inhibitory concentration: 3580 nM
Estimate against measurement, compound 4: 6.1-fold (0.79 log units) above; the measured number lies below the stated range.
By their numbers in this assay, from the lowest: compounds 4 and 1 (each within the scatter of the next); then compound 2; then compound 3.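

In this assay, the amide aryl place on the carbonyl carbon accepts a ring with a hetero atom, and a 13-fold lower number from compound 3 to compound 4 (1.11 log units; beyond the scatter) is the only step labelled large among the compounds shown, while a 4.6-fold lower number from compound 2 to compound 4 (0.66 log units; beyond the scatter) separates the 6-chloropyridin-3-yl amide from the 3-methylphenyl amide as well. Against the 4-methylphenyl amide the new group gives no distinguishable change, a 1.9-fold lower number from compound 1 to compound 4 (0.29 log units; within the scatter), so two differently built rings, one carbon-only and one with a hetero atom, now share the low end of the series, and the presence of a hetero atom alone does not set the read-out apart. Nothing measured on these compounds accounts for the size of the step away from the 4-bromo-2-fluorophenyl amide.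

The change from compound 3 to compound 4 replaces the ring type and the halogens together, so the compounds shown do not separate the share of the ring nitrogen, the chlorine, the bromine or the fluorine. Open questions are how a plain pyridin-3-yl, a 4-bromophenyl or a 6-aminopyridin-3-yl would read at this place, and whether a carboxylic acid on the ring would be accepted.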